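Compound 3 to compound 4: one aryl group for another

The source may hold more compounds than are shown below. What is called first, only, known or untested is meant among the compounds shown, and "the series" means these compounds.

In a functional assay on BT-483 cells (Homo sapiens) for cytotoxicity, read by MTT assay, with a stated time of 24 h (a higher number here means a weaker inhibitor, a lower number a stronger inhibitor), compound 3 `CCNc1cc(-c2ccc(NC(=O)Nc3cccc4ccccc34)cc2C(F)(F)F)ccn1` gives only a limit, > 30000 nM, and no number. Within the data shown here, the series so far holds (the limit of > 30000 nM in this assay, at which 1 of the 3 values shown sits).

Compound 1 `CCNc1cc(-c2ccc(NC(=O)Nc3cccc(Cl)c3)cc2C(F)(F)F)ccn1` gives 13300 nM in this assay, and compound 2 `CCNc1cc(-c2ccc(NC(=O)Nc3ccc(OC)cc3)cc2C(F)(F)F)ccn1` gives 17600 nM. Placing 4-methoxyphenyl where 3-chlorophenyl stood gives a 1.3-fold higher number from compound 1 to compound 2 (0.12 log units; within the scatter). Naphthalen-1-yl gives an at least 2.2-fold higher number from compound 1 to compound 3 (0.35 log units; beyond the scatter), and against 4-methoxyphenyl it gives an at least 1.7-fold higher number from compound 2 to compound 3 (0.23 log units; that floor lies within the scatter). Among the measured compounds shown here, only the step from the 3-chlorophenyl compound clears the scatter.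

Compound 4 `CCNc1cc(-c2ccc(NC(=O)Nc3c(C)cccc3C)cc2C(F)(F)F)ccn1` carries 2,6-dimethylphenyl in place of naphthalen-1-yl on an amide-type nitrogen. For the measured compounds named here, no measured compound carries 2,6-dimethylphenyl, so the estimate rests on analogy. Like compound 1 and compound 2, compound 4 has a single aromatic ring at this place, and those two differ only by a 1.3-fold higher number from compound 1 to compound 2 (0.12 log units; within the scatter). Compound 4 is therefore expected to read near them, though somewhat toward the naphthalen-1-yl end, and a reading at the limit of the assay remains possible. The step expected in this assay is small and toward a lower number: an at least 1.3-fold lower number from compound 3 to compound 4 (0.13 log units; that floor lies within the scatter). For compound 4 the estimated value is 22000 nM, with an expected range of 11000 nM to 42000 nM.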

Compound 4, half-maximal inhibitory concentration: 22000 nM
The estimate for compound 4 equals the measured number at the digits printed; measured number inside the range.
By their numbers in this assay, from the lowest: compounds 1, 2 and 4 (each within the scatter of the next). At a limit, above all of these: compound 3.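

In this assay, 2,6-dimethylphenyl on the amide-type nitrogen cannot be separated from either earlier single-ring group: a 1.3-fold higher number from compound 2 to compound 4 (0.10 log units; within the scatter), and a 1.7-fold higher number from compound 1 to compound 4 (0.22 log units; within the scatter). Across compounds 1, 2 and 4, the 3-chlorophenyl, 4-methoxyphenyl and 2,6-dimethylphenyl groups therefore give no readable difference, even though only 2,6-dimethylphenyl carries two substituents on its ring. Against naphthalen-1-yl the step is an at least 1.3-fold lower number from compound 3 to compound 4 (0.13 log units; that floor lies within the scatter), so going from two aromatic rings to one is not shown to matter here, and the only step in the series that clears the scatter remains the earlier one from the 3-chlorophenyl compound to compound 3, whose value is a limit and not a number: the limit of > 30000 nM in this assay, at which 1 of the 4 values shown sits.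

As far as these compounds go, all four groups at this place are carbon-only aromatic rings with simple substituents, so it remains open whether a pyridine ring, an aryl group bearing a carboxylic acid or an amine, or a plain alkyl chain would move the number beyond the scatter. The rest of the core is the same in all four compounds, so these data say nothing about its contribution.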